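This account rests on a few compounds, and the source may have more. Where it says the series, first, only, none or still open, it means among the compounds named here.

Of the compounds shown here, three sharing one core have been measured so far. In a functional assay on A-375 cells (Homo sapiens) for antiproliferative activity, read by MTT assay, with a stated time of 48 h (on this read-out higher numbers stand for weaker inhibition of growth and lower numbers for stronger inhibition of growth), compound 1 `S=C(Nc1ccccc1)N1N=C(c2ccccc2)CC1c1ccc2c(c1)OCCO2` gives 1850 nM. Compound 2 `Fc1ccc(C2=NN(C(=S)Nc3ccccc3)C(c3ccc4c(c3)OCCO4)C2)cc1` gives 15700 nM in this assay, and compound 3 `Cc1ccc(C2=NN(C(=S)Nc3ccccc3)C(c3ccc4c(c3)OCCO4)C2)cc1` gives 6320 nM. Compound 2 thus stands highest of the three: its nearest neighbour is compound 3, reached by a 2.5-fold lower number from compound 2 to compound 3 (0.40 log units; beyond the scatter), and its furthest is compound 1, from which it is separated by an 8.5-fold higher number from compound 1 to compound 2 (0.93 log units; beyond the scatter). Compound 4 `FC(F)(F)c1ccc(C2=NN(C(=S)Nc3ccccc3)C(c3ccc4c(c3)OCCO4)C2)cc1` has not yet been measured. It differs from compound 2 by trifluoromethyl in place of fluoro on an aromatic carbon. Within the data shown here, no measured step exchanges fluoro for trifluoromethyl. Among the measured compounds shown here, the steps that bear on it are those at the same aromatic carbon, an 8.5-fold higher number from compound 1 to compound 2 (0.93 log units; beyond the scatter), a 3.4-fold higher number from compound 1 to compound 3 (0.53 log units; beyond the scatter) and a 2.5-fold lower number from compound 2 to compound 3 (0.40 log units; beyond the scatter), all modest, and they show that each group placed there gives a higher number than hydrogen, with fluoro the highest. Nothing shows how trifluoromethyl compares with fluoro there. A step of a 1.1-fold lower number from compound 2 to compound 4 (0.05 log units; within the scatter) is expected, small and of uncertain direction. Compound 4 is therefore estimated at 14000 nM, with a range from 4500 nM to 45000 nM.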

Compound 4, concentration for 50% growth inhibition: 43500 nM
Compound 4: the middle estimate sits 3.1-fold (0.49 log units) below what was measured; low and high end bracket the measured number.
By their numbers in this assay, from the lowest: compound 1; then compound 3; then compound 2; then compound 4.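

At the aromatic carbon para to a large group in this assay, fluoro no longer marks the upper end of the series, since trifluoromethyl goes beyond it (a 2.8-fold higher number from compound 2 to compound 4 (0.44 log units; beyond the scatter)) and further beyond methyl (a 6.9-fold higher number from compound 3 to compound 4 (0.84 log units; beyond the scatter)), which leaves compound 4 the weakest inhibitor of growth of the four. Measured against hydrogen, this is the first large change at this place (a 24-fold higher number from compound 1 to compound 4 (1.37 log units; beyond the scatter)), and hydrogen still gives the lowest number, with no group shown here going against that. No measurement shown here explains this order.

On these data alone, it remains open whether any group at this carbon, such as an amine, a hydroxyl or a methoxy group, could give a lower number than hydrogen. As far as these compounds go, whether trifluoromethyl or fluoro would rank the same way on another carbon of this ring also remains open.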